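This account rests on a few compounds, and the source may have more. Where it says the series, first, only, none or still open, it means among the compounds named here.

Compounds built on one shared core were examined in an in vitro functional assay on CHO-CREluc cells for antagonist activity at growth hormone secretagogue receptor type 1 (Homo sapiens), read by a luciferase reporter, with a stated time of 4 h; on this read-out lower numbers stand for stronger inhibition and higher numbers for weaker inhibition. Compound 2 `CN1CCN(CC(=O)NC2(c3ccc(Cl)c(Cl)c3)C(=O)Nc3cc(Cl)ccc32)CC1` stands lowest of the two numbers given: in this assay compound 2 gives 111 nM. Compound 3 `Cc1cc2c(cc1Cl)C(NC(=O)CN1CCN(C)CC1)(c1ccc(Cl)cc1)C(=O)N2` is its nearest neighbour, and in this assay compound 3 gives 251 nM. Compound 1 `CN1CCN(CC(=O)NC2(c3ccc(Cl)cc3)C(=O)Nc3cc(Cl)c(Cl)cc32)CC1` reaches only a limit of the assay, since in this assay compound 1 gives > 10000 nM. Compound 4 `CN1CCN(CC(=O)NC2(c3ccc(Cl)cc3)C(=O)Nc3cc(Cl)ccc32)CC1` has not yet been measured. It differs from compound 2 in a single place: hydrogen in place of chloro on an aromatic carbon. Among the compounds with values here, the only step between measured compounds that is known concerns a different place, on the core ring: an at least 39-fold lower number from compound 1 to compound 3 (1.60 log units; beyond the scatter), a step that runs from the limit of > 10000 nM in this assay, at which 1 of the 3 values shown sits, down to a number. Within the data shown here, no measured pair differs by the change from compound 2 to compound 4, so no step bears on it directly. Compound 4 does share its 4-chlorophenyl group with compound 3, which gives 251 nM. A modest step upward is therefore expected in this assay, a 2.7-fold higher number from compound 2 to compound 4 (0.43 log units; beyond the scatter), close to the edge of the scatter. Compound 4 is estimated at 300 nM, with a range from 80 nM to 1500 nM.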

Compound 4, half-maximal inhibitory concentration: 140 nM
For compound 4 the middle estimate is 2.1-fold (0.33 log units) above the measured one; the range from low to high includes it.
By their numbers in this assay, from the lowest: compounds 2, 4 and 3 (each within the scatter of the next, the first and the last beyond it). At a limit, above all of these: compound 1.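

On the aryl group, the change from 3,4-dichlorophenyl to 4-chlorophenyl had not been read before, and in this assay it gives a 1.3-fold higher number from compound 2 to compound 4 (0.10 log units; within the scatter), so at this position the two compounds cannot be told apart and the extra chloro group shows no measurable effect on inhibition. The same kind of replacement on the core reads very differently, with an at least 71-fold lower number from compound 1 to compound 4 (1.85 log units; beyond the scatter), a large step that shows the effect of hydrogen in place of chloro depends strongly on where the change is made. Compound 1 stands at a limit and not at a number, so this second step gives only a lower bound on its size: the limit of > 10000 nM in this assay, at which 1 of the 4 values shown sits.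

The compounds shown leave open whether a group other than chloro or hydrogen at this place, such as a fluoro, methoxy or amine group, would keep the same level of inhibition. They also leave open what happens when the remaining chloro of the 4-chlorophenyl group gives way to hydrogen, since every compound shown still carries it.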